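Thiophene sulfonamide ureas: aryl ether to cyclohexyl ether

The source may hold more compounds than are shown below. What is called first, only, known or untested is meant among the compounds shown, and "the series" means these compounds.

Two members of the series have been run in a functional assay on HL-60 cells (Homo sapiens) for inhibition, read by CCK-8 assay, with a stated time of 48 h; a lower number here means a stronger inhibitor, a higher number a weaker inhibitor. Compound 1 `O=[N+]([O-])c1ccc(NC(=S)NCCNS(=O)(=O)c2ccc(-c3ccccc3OCc3ccccc3)s2)cc1` returns only a limit in this assay, > 50000 nM, so it is not a number that can be compared. Within the data shown here, compound 2 `O=C(NCCNS(=O)(=O)c1ccc(-c2ccccc2Oc2ccc([N+](=O)[O-])c([N+](=O)[O-])c2)s1)Nc1cc(C(F)(F)F)cc(C(F)(F)F)c1` gives 1900 nM in this assay and is therefore the only member with a measured number; the other entry sits at the limit of > 50000 nM in this assay, at which 1 of the 2 values shown sits. Among the measured compounds shown here, no step between two measured compounds is available, so the size of any change has to be estimated from the structures alone.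

Compound 3 `O=C(NCCNS(=O)(=O)c1ccc(-c2ccccc2O[C@H]2CC[C@H](O)CC2)s1)Nc1cc(C(F)(F)F)cc(C(F)(F)F)c1` is the next candidate. It differs from compound 2 in one place: 4-hydroxycyclohexyl in place of 3,4-dinitrophenyl on an oxygen on an aromatic ring. For the measured compounds named here, with no measured step on this oxygen to lean on, a modest loss is expected, so the step from compound 2 to compound 3 in this assay is estimated at a 2.4-fold higher number from compound 2 to compound 3 (0.37 log units; beyond the scatter). Compound 3 is therefore expected to give about 4500 nM in this assay, with a plausible range from 1000 nM to 25000 nM.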

Compound 3, half-maximal inhibitory concentration: 7100 nM
Beside the measured number, compound 3's estimate is 1.6-fold (0.20 log units) below it; low and high end bracket the measured number.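

Among these compounds, the first readable step sits on the oxygen on an aromatic ring: in this assay, 4-hydroxycyclohexyl in place of 3,4-dinitrophenyl gives a 3.7-fold higher number from compound 2 to compound 3 (0.57 log units; beyond the scatter). The aromatic ring and its nitro groups are therefore not required for a measured number at this position, as a non-aromatic ring carrying a hydroxyl still gives one, though at a modest loss. Nothing measured among the compounds shown accounts for the size of this step.

The compounds shown do not separate the loss of the aromatic ring from the loss of the nitro groups or the gain of the hydroxyl. A plain phenyl, an unsubstituted cyclohexyl or a 4-aminocyclohexyl on the same oxygen would pull these contributions apart.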